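The compounds below may be only part of what the source reports. "The series", "measured", "known", "first", "only" and "open" are said of these compounds alone.

Compound 1, `CC(C)=CCC/C(C)=C/CC1Cc2c(O)cc(=O)n(CCCO)c2CC1(C)C`, and compound 2, `CC(C)=CCC/C(C)=C/CC1Cc2c(OCCCNS(=O)(=O)c3ccc(Cl)cc3)cc(=O)n(CCCO)c2CC1(C)C`, share a core; compound 2 carries a longer side chain ending in a sulfonamide. In a functional assay on PANC-1 cells (Homo sapiens) for inhibition, read by MTT assay, with a stated time of 24 h, tested at 10 uM (a higher number here means more inhibition at the concentration tested (going by the name of the read-out), a lower number less inhibition), compound 1 gives 0%. In this assay compound 2 gives 16.1%, the higher of the two numbers, and its gap to compound 1 lies beyond the usual scatter. Compound 3, `COc1ccc(OCCCOc2cc(=O)n(CCCO)c3c2CC(C/C=C(\C)CCC=C(C)C)C(C)(C)C3)cc1`, has not yet been measured. It differs from compound 2 in one place: 4-methoxyphenoxy in place of ((4-chlorophenyl)sulfonyl)amino on a saturated chain carbon, three bonds along the chain from an oxygen on an aromatic ring. Within the data shown here, with only two measured compounds and no step recorded between compounds that differ in a single place, there is little to guide the direction. The step of a number 6.1 percentage points lower from compound 2 to compound 3 (within the scatter) is expected to be small, slightly downward, and not beyond the scatter. Compound 3 is therefore estimated to give 10%, with a likely range from 0% to 25%.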

Compound 3, a percentage reported as inhibition, at one concentration (the size of the read-out at that concentration, not a potency): 0%
The estimate for compound 3 lay 10 percentage points above the measured number, and the stated range covers the measured number.
By their numbers in this assay, from the lowest: compounds 1 and 3 (each within the scatter of the next); then compound 2.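

In this assay, placing 4-methoxyphenoxy where ((4-chlorophenyl)sulfonyl)amino stood on the same saturated chain carbon gives a step of a number 16.1 percentage points lower from compound 2 to compound 3 (beyond the scatter), so the read-out at this position depends on which group ends the chain, and an aromatic ring of carbon at that end does not suffice. Putting 3-(4-methoxyphenoxy)propyl in place of hydrogen on the oxygen on the aromatic ring gives no change at the digits printed from compound 1 to compound 3 (within the scatter), which shows that lengthening this side chain does not in itself raise the number. No supporting measurement bears on why these two end groups differ.

As far as these compounds go, whether the effect in compound 2 rests on the sulfonyl, the nitrogen or the chlorine remains open. So does the outcome with a simple amine or a carboxylic acid at the chain end.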